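Removing one chloro from the amide aryl of compound 2

This account rests on a few compounds, and the source may have more. Where it says the series, first, only, none or still open, it means among the compounds named here.

Measured so far in an ADME assay on a cell-free system (plasma, Homo sapiens) for protein binding; a lower number here means a smaller unbound share, a higher number a larger unbound share of the compound:
- compound 1 `Cn1cnc(S(=O)(=O)N2C[C@@H]3[C@H](C2)[C@@]3(CNC(=O)c2ccc(Cl)cc2Cl)CC2CC2)c1` gives 0.05
- compound 2 `Cn1cnc(S(=O)(=O)N2C[C@@H]3[C@H](C2)[C@@]3(CNC(=O)c2c(Cl)cccc2Cl)CC2CC2)c1` gives 0.08

Compound 2 has the highest of the two numbers in this assay, yet the step of a 1.6-fold higher number from compound 1 to compound 2 (0.20 log units; within the scatter) keeps it within the scatter of compound 1. Compound 3 `Cn1cnc(S(=O)(=O)N2C[C@@H]3[C@H](C2)[C@@]3(CNC(=O)c2ccccc2Cl)CC2CC2)c1` differs from compound 2 by hydrogen in place of chloro on an aromatic carbon. No measured step removes a chloro; the only step shown, from compound 1 to compound 2, merely moves one and stays within the scatter. Compound 3 is therefore expected to show a small upward step a 1.5-fold higher number from compound 2 to compound 3 (0.18 log units; within the scatter), within the scatter. Compound 3 is estimated at 0.12, between 0.06 and 0.25.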

Compound 3, unbound fraction: 0.03
Compound 3: middle estimate off by 4.0-fold (0.60 log units), on the high side; the whole stated range lies above it.
By their numbers in this assay, from the lowest: compounds 3, 1 and 2 (each within the scatter of the next, the first and the last beyond it).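

In this assay, among these compounds, taking a chloro off the 2,6-dichlorophenyl group gives the first step here beyond the scatter (a 2.7-fold lower number from compound 2 to compound 3 (0.43 log units; beyond the scatter)), so the change at this place on the aromatic ring can be read. The same exchange of chloro for hydrogen, starting from the 2,4-dichlorophenyl group, stays within the scatter (a 1.7-fold lower number from compound 1 to compound 3 (0.22 log units; within the scatter)), so its size depends on the aryl group it starts from. Nothing available explains this difference. Going by these compounds, whether a fluoro or a methoxy in place of this chloro would shift the unbound fraction remains open. Where a phenyl carrying no chloro would fall also remains open.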